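This account rests on a few compounds, and the source may have more. Where it says the series, first, only, none or still open, it means among the compounds named here.

Working notes on the series.

Compound 1 `CCC(CO)NCc1nc2c(OCC3CCCCC3)cccc2[nH]1` is the reference point. In an assay on cells for inhibition of interleukin-5 receptor subunit alpha (Mus musculus), read by WST assay, with a stated time of 48 h, in the presence of a further agent that is not named here (on this read-out lower numbers stand for stronger inhibition and higher numbers for weaker inhibition), compound 1 gives 3500 nM, the lowest of the three numbers recorded so far. Compound 3 `OCC(CC1CCCCC1)NCc1nc2c(OCC3CCCCC3)cccc2[nH]1` stands nearest to it: in this assay compound 3 gives 5000 nM, and the step of a 1.4-fold higher number from compound 1 to compound 3 (0.15 log units; within the scatter). Among the measured compounds shown here, compound 2 `OCCC(NCc1nc2c(OCC3CCCCC3)cccc2[nH]1)c1ccccc1` is furthest away: in this assay compound 2 gives 22000 nM, and its gap to compound 1 lies beyond the scatter, though no single-point step has been worked out for that pair.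

The next compound to be read is compound 4 `COc1ccc(NCc2nc3c(OCC4CCCCC4)cccc3[nH]2)cc1`. Its change from compound 1 is 4-methoxyphenyl in place of 1-(hydroxymethyl)propyl on an amine nitrogen. For the measured compounds named here, none of the measured steps bears directly on this: the step from compound 1 to compound 3 alters a chain carbon two bonds from the amine nitrogen and leaves the hydroxyl-bearing substituent intact, whereas in compound 4 that substituent is removed entirely and an aromatic ring takes its place. Every measured compound carries a hydroxyl on the amine substituent; compound 4 does not, and nothing in the data shows what that costs or gains.

The expectation for compound 4 is therefore wide and centred a little above compound 1, at 8000 nM with a range of 2000 nM to 40000 nM, meaning an expected step of a 2.3-fold higher number from compound 1 to compound 4 (0.36 log units; beyond the scatter).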

Compound 4, half-maximal inhibitory concentration: > 30000 nM
Compound 4 gave a limit, no number; the forecaster's own chance of this, stated with the estimate: 15%; middle value at least 3.7-fold (0.57 log units) away from the limit.
By their numbers in this assay, from the lowest: compounds 1 and 3 (each within the scatter of the next); then compound 2. At a limit, above all of these: compound 4.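

Compound 4 is the first change shown at the amine nitrogen itself, not on a chain carbon further out, and it matters far more here. In this assay, 4-methoxyphenyl in place of 1-(hydroxymethyl)propyl gives an at least 8.5-fold higher number from compound 1 to compound 4 (0.93 log units; beyond the scatter), whereas the chain change gives only a 1.4-fold higher number from compound 1 to compound 3 (0.15 log units; within the scatter); tolerance of that chain change therefore does not extend to this replacement of the whole substituent. Compound 4 gives a limit of the assay and not a number, so the step has a lower bound but no measured size: the limit of > 30000 nM in this assay, at which 1 of the 4 values shown sits.

The change removes the hydroxyl and brings in an aromatic ring and a methoxy group in one step, so the compounds shown do not separate these contributions to the loss. A plain propyl group on the amine nitrogen would test the hydroxyl with no aromatic ring present, while an unsubstituted phenyl or a 4-hydroxyphenyl group at the same place would show whether the methoxy group plays any part and whether restoring a hydroxyl on the aromatic ring recovers a measurable number.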